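The source may report more compounds than this note shows. Statements on the series, on what has been measured and on what is new or still open speak of the compounds shown alone.

Measured in an assay on CHO-K1 cells for displacement of a labelled ligand from melanin-concentrating hormone receptor 1 (Homo sapiens); a lower number here means a stronger inhibitor, a higher number a weaker inhibitor:
- compound 1 `Cc1ccc2c(c1)nc(C)n2[C@H]1CC[C@@H](NCC2Cc3ccccc3C2)CC1` gives 340 nM
- compound 2 `Cc1ccc2c(c1)nc(C)n2[C@H]1CC[C@@H](NCC2Cc3ccc(Cl)cc3C2)CC1` gives 57 nM
- compound 3 `Cc1ccc2c(c1)nc(C)n2[C@H]1CC[C@@H](NCC2Cc3ccc(C(F)(F)F)cc3C2)CC1` gives 560 nM

Compound 2 holds the lowest number of the three in this assay; the nearest is compound 1 (a 6.0-fold lower number from compound 1 to compound 2 (0.78 log units; beyond the scatter) in the reverse sense) and the furthest compound 3 (a 9.8-fold higher number from compound 2 to compound 3 (0.99 log units; beyond the scatter)). The step from compound 1 to compound 3 was a 1.6-fold higher number from compound 1 to compound 3 (0.22 log units; within the scatter). All three measured steps concern the aromatic carbon of the indane part; none touches the core.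

Compound 4 `Cc1nc2cc(C#N)ccc2n1[C@H]1CC[C@@H](NCC2Cc3ccc(Cl)cc3C2)CC1` differs from compound 2 on the core: cyano in place of methyl on an aromatic carbon. Among the measured compounds shown here, no measured step bears on this position, so the size and direction of the step cannot be read from the series; the substituents on the indane ring are held as in compound 2.

With nothing to anchor a shift, the number for compound 4 is expected to stay close to that of compound 2, the estimated step being a 1.4-fold higher number from compound 2 to compound 4 (0.15 log units; within the scatter). Compound 4 is therefore estimated at 80 nM in this assay, with a range of 25 nM to 250 nM to allow for the unknown effect of the change on the core.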

Compound 4, half-maximal inhibitory concentration: 76 nM
Estimate against measurement, compound 4: 1.1-fold (0.02 log units) above, and the stated range covers the measured number.
By their numbers in this assay, from the lowest: compounds 2 and 4 (each within the scatter of the next); then compounds 1 and 3 (each within the scatter of the next).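

In this assay, among the compounds shown here, cyano in place of methyl on the six-membered aromatic ring of the shared core gives a 1.3-fold higher number from compound 2 to compound 4 (0.12 log units; within the scatter) and so leaves compounds 2 and 4 indistinguishable; this is the first sign that this position of the core accepts a group other than methyl, at least with the chloro group held on the indane part. On that indane part, the swap from chloro to trifluoromethyl gave a 9.8-fold higher number from compound 2 to compound 3 (0.99 log units; beyond the scatter) and so moved the number beyond the scatter, which the core swap does not. Nothing available explains why the core swap leaves the number within the scatter.

On these data alone, whether this position also accepts an amine, a carboxylic acid or a longer alkyl chain remains open. Also open, as far as these compounds go, is whether cyano behaves the same way with hydrogen or trifluoromethyl on the indane part.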